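The compounds below may be only part of what the source reports. "The series", "measured", "known", "first", "only" and "open" are said of these compounds alone.

Measured to date:
- compound 1 `CC(C)CCn1cnc2c(NCc3cccc(Cl)c3)nc(N[C@H]3CC[C@H](N)CC3)nc21` — 4700 nM
- compound 2 `CCCCn1cnc2c(Nc3cccc(Cl)c3)nc(N[C@H]3CC[C@H](N)CC3)nc21` — 2000 nM
- compound 3 `N[C@H]1CC[C@H](Nc2nc(Nc3cccc(Cl)c3)c3ncn(Cc4ccccc4)c3n2)CC1` — 3600 nM

Compound 1 gives the highest of the three numbers in a functional assay on MCF7 cells (Homo sapiens) for inhibition, read by fluorescence, with a stated time of 72 h; on this read-out higher numbers stand for weaker inhibition of growth and lower numbers for stronger inhibition of growth. Against compound 3 the gap is within the scatter; against compound 2 it is beyond it, though compound 1 and compound 2 differ in two places, so no single step can be read from that pair. Among the compounds with values here, the one measured step, a 1.8-fold higher number from compound 2 to compound 3 (0.26 log units; within the scatter), is within the scatter.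

Compound 4 `CC(C)CCn1cnc2c(Nc3ccc(O)cc3)nc(N[C@H]3CC[C@H](N)CC3)nc21` is made from compound 1 by 4-hydroxyphenyl in place of 3-chlorobenzyl on a nitrogen on an aromatic ring. Within the data shown here, no measured step covers this change: the measured step concerns the saturated chain carbon bound to an aromatic nitrogen, not the group on the ring nitrogen, and no pair shows a change from chlorine to a hydroxyl on that ring. Among the measured compounds shown here, the only pointer is that compound 2, which carries an aryl directly on that nitrogen, gives 2000 nM, lower than compound 1, but with a second difference present. For compound 4 the expected step is therefore a 1.6-fold lower number from compound 1 to compound 4 (0.19 log units; within the scatter), a modest move toward a lower number with wide uncertainty. Compound 4 is estimated at 3000 nM, between 800 nM and 12000 nM.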

Compound 4, concentration for 50% growth inhibition: 3100 nM
For compound 4 the middle estimate is 1.0-fold (0.01 log units) below the measured one; low and high end bracket the measured number.
By their numbers in this assay, from the lowest: compounds 2, 4, 3 and 1 (each within the scatter of the next, the first and the last beyond it).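

In this assay, 4-hydroxyphenyl in place of 3-chlorobenzyl on a nitrogen on an aromatic ring gives a 1.5-fold lower number from compound 1 to compound 4 (0.18 log units; within the scatter), the first step read at this position. The swap removes the chlorine, enters a hydroxyl with its hydrogen-bond donor and acceptor, and goes from 8 to 7 heavy atoms, yet the number stays within the scatter, so this position accepts both groups on this read-out. No other data bear on the reason for this result.

The step changes several features at once, so the effects of the chlorine, the hydroxyl and the benzyl carbon cannot be separated. As far as these compounds go, whether an amine or a carboxylic acid in place of the hydroxyl, or a longer chain between the nitrogen and the ring, would move the number beyond the scatter remains open.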